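Chain length at the aryl ether of a flavanone core

The compounds below may be only part of what the source reports. "The series", "measured", "known", "first", "only" and "open" are said of these compounds alone.

Measured compounds:
compound 1 `O=C1CC(c2ccccc2OCc2ccc(F)cc2)Oc2ccccc21` — 45.2%
compound 2 `CC(C)CCOc1ccccc1C1CC(=O)c2ccccc2O1` — 47.6%
compound 3 `CC(C)COc1ccccc1C1CC(=O)c2ccccc2O1` — 30.4%

In a functional assay on RAW264.7 cells (Mus musculus) for inhibition, read by immunoassay, with a stated time of 12 h, tested at 30 uM (on this read-out lower numbers stand for less inhibition and higher numbers for more inhibition at the one concentration tested (going by the name of the read-out)), compound 3 gives the lowest of the three numbers; compound 1 stands higher by a number 14.8 percentage points lower from compound 1 to compound 3 (beyond the scatter) reversed in sense, and compound 2 stands higher still, as the step of a number 17.2 percentage points lower from compound 2 to compound 3 (beyond the scatter) shows. The step from compound 1 to compound 2 is a number 2.4 percentage points higher from compound 1 to compound 2 (within the scatter).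

Compound 4 `CCCCCOc1ccccc1C1CC(=O)c2ccccc2O1` differs from compound 3 by butyl in place of isopropyl on a saturated chain carbon bound to an oxygen on an aromatic ring. The step that bears most on this change is a number 17.2 percentage points lower from compound 2 to compound 3 (beyond the scatter), where shortening the group on the saturated chain carbon bound to an oxygen on the aromatic ring lowered the number. The move from compound 3 to compound 4 runs the other way, lengthening that group to pentyl in place of isobutyl, so a rise beyond the scatter is expected, roughly back toward the level of compound 2. Compound 4 is therefore estimated at 43%, with a range of 30% to 56%, a step of a number 12.6 percentage points higher from compound 3 to compound 4 (beyond the scatter).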

Compound 4, a percentage reported as inhibition, at one concentration (the size of the read-out at that concentration, not a potency): 41.3%
For compound 4 the middle estimate is 1.7 percentage points above the measured one; low and high end bracket the measured number.
By their numbers in this assay, from the lowest: compound 3; then compounds 4, 1 and 2 (each within the scatter of the next).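

In this assay, compound 3 no longer stands alone as the single short-chain case set against compound 2: the change from isobutyl to pentyl, read as a number 10.9 percentage points higher from compound 3 to compound 4 (beyond the scatter), shows that a longer group at this oxygen can raise the number without the branching found in compound 2. Placing propyl where isopropyl stood, on a saturated chain carbon two bonds along the chain from an oxygen on an aromatic ring, gives a number 6.3 percentage points lower from compound 2 to compound 4 (within the scatter), so the straight chain and the branched chain cannot be told apart at this length. Butyl in place of 4-fluorophenyl gives a number 3.9 percentage points lower from compound 1 to compound 4 (within the scatter), which leaves compound 3 as the only one of the four set apart from the others, and no measurement at hand explains this.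

The compounds shown leave open whether the number would stay at this level, rise or fall with a longer chain such as octyl. They also leave open what an amine or a carboxylic acid at the end of the chain would do to the number in this assay.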